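Hexyl to Methyl: Expected Cytotoxicity of a Shortened Chain

This account rests on a few compounds, and the source may have more. Where it says the series, first, only, none or still open, it means among the compounds named here.

Three measured compounds share one core. Compound 1, `CCCCCCc1ccc(NC(=O)c2cc([N+](=O)[O-])ccc2F)cc1`, in an ADME assay on HepG2 cells (Homo sapiens) for cytotoxicity, with a stated time of 72 h (on this read-out higher numbers stand for weaker inhibition and lower numbers for stronger inhibition), gives 2500 nM. Compound 2, `CCCCCCc1ccc(NC(=O)c2cc([N+](=O)[O-])ccc2Cl)cc1`, in this assay gives only > 50000 nM, which is a limit of the assay rather than a number. Compound 3, `CCCCCCc1ccc(NC(=O)c2ccc([N+](=O)[O-])cc2Cl)cc1`, in this assay likewise gives only the limit > 50000 nM. Among the measured compounds shown here, the one measured step, an at least 20-fold higher number from compound 1 to compound 2 (1.30 log units; beyond the scatter), therefore runs from a real number up to the limit, and compound 2 stands at the limit of > 50000 nM in this assay, at which 2 of the 3 values shown sit, alongside compound 3, with no number of its own.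

Compound 4, `Cc1ccc(NC(=O)c2cc([N+](=O)[O-])ccc2Cl)cc1`, differs from compound 2 by hydrogen in place of pentyl on a saturated chain carbon bound to an aromatic carbon. No measured step touches this chain: the only step shown swaps a halogen on the ring, so it says nothing about trimming hexyl to methyl. For the measured compounds named here, compound 2 already sits where the assay stops counting, and a change on the chain has no measured precedent here, so the step expected, a step that the limit leaves unreadable from compound 2 to compound 4, is none beyond the scatter. Compound 4 is thus expected to give 60000 nM in this assay, with a range from 15000 nM to 200000 nM, most likely reported again as a limit.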

Compound 4, half-maximal inhibitory concentration: > 50000 nM
Compound 4 gave a limit, no number; the forecaster's own chance of this, stated with the estimate: 75%; the middle value is on the limit's open side.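

Compound 2 and compound 4 each stand only at a limit in this assay, not at a number, and the step between them cannot be read. The compounds shown leave open whether going from hexyl to methyl changes cytotoxicity at all: no pair differing only in that chain has a real number on both sides.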